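The source may hold more compounds than are shown below. What is called first, only, known or untested is meant among the compounds shown, and "the series" means these compounds.

In a functional assay on HCT-116 cells (Homo sapiens) for inhibition, read by MTT assay, with a stated time of 72 h (a lower number here means a stronger inhibitor, a higher number a weaker inhibitor), compound 3, `CCOC(=O)c1oc2ccc(N(Cc3ccccc3)S(=O)(=O)c3ccc(C(F)(F)F)cc3)cc2c1C`, gives 26700 nM. Compound 1, `CCOC(=O)c1oc2ccc(N(Cc3ccccc3)S(=O)(=O)c3ccc(Br)cc3)cc2c1C`, gives 9460 nM in this assay, and the step of a 2.8-fold higher number from compound 1 to compound 3 (0.45 log units; beyond the scatter) is modest. Compound 2, `CCOC(=O)c1oc2ccc(N(Cc3ccccc3)S(=O)(=O)c3ccc([N+](=O)[O-])cc3)cc2c1C`, reaches in this assay only a limit, > 40000 nM, which is not a number. Among the plain numbers, compound 3 therefore stands highest, with compound 1 nearest. The step to compound 4, `CCOC(=O)c1oc2ccc(N(Cc3ccccc3)S(=O)(=O)c3ccccc3)cc2c1C`, changes (hydrogen in place of trifluoromethyl on an aromatic carbon). Within the data shown here, none of the measured steps removes the group altogether: an at least 4.2-fold higher number from compound 1 to compound 2 (0.62 log units; beyond the scatter) and an at least 1.4-fold lower number from compound 2 to compound 3 (0.17 log units; that floor lies within the scatter) only swap one group for another, so the direction for compound 4 is open and a value near compound 1 or compound 3 seems plausible. Compound 4 is thus expected to give 15000 nM, between 5000 nM and 45000 nM. That expectation means a step of a 1.8-fold lower number from compound 3 to compound 4 (0.25 log units; within the scatter).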

Compound 4, half-maximal inhibitory concentration: > 40000 nM
Compound 4: no number, only a limit (the forecaster's own chance of this, stated with the estimate: 25%); middle value at least 2.6-fold (0.42 log units) from the limit.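

Compound 4, which carries phenyl in place of 4-(trifluoromethyl)phenyl, gives only a limit, not a number. With no group at this place, the loss is clear against bromo (an at least 4.2-fold higher number from compound 1 to compound 4 (0.62 log units; beyond the scatter)), while trifluoromethyl is not separated from hydrogen (an at least 1.4-fold higher number from compound 3 to compound 4 (0.17 log units; that floor lies within the scatter)), so among these compounds only bromo clearly improves on hydrogen. The step between compound 2 and compound 4 cannot be read, because both stand at a limit: (the limit of > 40000 nM in this assay, at which 2 of the 4 values shown sit).

Still open, on these data alone, is how an amine or a carboxylic acid would read at this place. As far as these compounds go, whether any group can improve on bromo also remains unknown.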